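Aryl swap at the chain carbon: working notes

The source may hold more compounds than are shown below. What is called first, only, known or untested is meant among the compounds shown, and "the series" means these compounds.

Measured so far
compound 1: `COc1cccc(C(C)Sc2nc3c(cnn3C)c(=O)n2-c2ccccc2)c1` — 108 nM
compound 2: `CC(Sc1nc2c(cnn2C)c(=O)n1-c1ccc(C#N)cc1)c1ccccc1` — 3100 nM

In an assay on isolated protein for inhibition of retinal dehydrogenase 2 (Homo sapiens) (a lower number here means a stronger inhibitor, a higher number a weaker inhibitor), compound 1 gives 108 nM, the lowest of the two numbers available. Compound 2 gives 3100 nM, a higher number and beyond the scatter. Compounds 1 and 2 differ in more than one place, so no single step can be read from that pair, and it says nothing about the chain carbon on its own.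

Compound 3 `CC(Sc1nc2c(cnn2C)c(=O)n1-c1ccccc1)c1cncnc1` is the next to be measured. Against compound 1 the change is pyrimidin-5-yl in place of 3-methoxyphenyl on a saturated chain carbon bound to a saturated chain carbon and a sulfur. No measured pair isolates a change at this carbon, so the direction cannot be anchored on a shown step; the working assumption is a moderate weakening, a loss somewhat beyond the scatter rather than a collapse. The expected step is a 3.0-fold higher number from compound 1 to compound 3 (0.47 log units; beyond the scatter). For compound 3 the estimate is 320 nM, with a range from 90 nM to 1500 nM.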

Compound 3, half-maximal inhibitory concentration: 380 nM
Compound 3: middle estimate off by 1.2-fold (0.07 log units), on the low side, within the range that was stated.
By their numbers in this assay, from the lowest: compound 1; then compound 3; then compound 2.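

The series now has its first step at a single place: in this assay, pyrimidin-5-yl in place of 3-methoxyphenyl on a saturated chain carbon bound to a saturated chain carbon and a sulfur gives a 3.5-fold higher number from compound 1 to compound 3 (0.55 log units; beyond the scatter). The aryl group at this carbon therefore bears on the number, yet this exchange of a carbon-only ring for a ring with 2 hetero atoms gives only a modest step. Nothing on hand accounts for the size or direction of this step.

Going by these compounds alone, compound 2 differs from compound 1 and compound 3 in more than one place, so it adds no step at this carbon. Still open, going by these compounds, is whether the change tracks the loss of the methoxy group or the arrival of the ring nitrogens, and how an amine or a carboxylic acid on the aryl ring at this carbon would read.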